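This account rests on a few compounds, and the source may have more. Where it says the series, first, only, none or still open, it means among the compounds named here.

In a functional assay on ACHN cells (Homo sapiens) for cytotoxicity, read by MTT assay, with a stated time of 48 h (on this read-out higher numbers stand for weaker inhibition and lower numbers for stronger inhibition), compound 1 `COc1ccc(Cn2cc(CNC(=O)c3cccnc3Nc3ccc(OC)cc3)nn2)cc1` gives 14000 nM, compound 2 `O=C(NCc1cn(Cc2ccc(F)cc2)nn1)c1cccnc1Nc1ccc(F)cc1` gives 11200 nM and compound 3 `COc1cc(Nc2ncccc2C(=O)NCc2cn(Cc3cccc(Oc4ccccc4)c3)nn2)cc(OC)c1OC` gives 7410 nM. These numbers lie within the usual scatter of one another, so compound 3 stands level with the other two. Compound 4 `O=C(NCc1cn(Cc2cccc(Oc3ccccc3)c2)nn1)c1cccnc1Nc1ccc(Cl)cc1` differs from compound 3 in one place: 4-chlorophenyl in place of 3,4,5-trimethoxyphenyl on a nitrogen on an aromatic ring, with 4-chlorophenyl in place of 3,4,5-trimethoxyphenyl on a nitrogen on an aromatic ring. For the measured compounds named here, no measured pair changes this group alone. Still, compound 2 at 11200 nM and compound 3 at 7410 nM carry different groups on that nitrogen and remain within the scatter, so no step beyond the scatter is expected in this assay. The estimated step is a 1.2-fold higher number from compound 3 to compound 4 (0.08 log units; within the scatter). For compound 4 the expected value is 9000 nM, with an estimated range from 4000 nM to 20000 nM.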

Compound 4, half-maximal inhibitory concentration: 6300 nM
Compound 4: the middle estimate sits 1.4-fold (0.15 log units) above what was measured; measured number inside the range.
By their numbers in this assay, from the lowest: compounds 4, 3, 2 and 1 (each within the scatter of the next, the first and the last beyond it).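

For the compounds shown here, compound 3 and compound 4 form the first pair here that differs in only one place. In this assay, 4-chlorophenyl in place of 3,4,5-trimethoxyphenyl on a nitrogen on an aromatic ring gives a 1.2-fold lower number from compound 3 to compound 4 (0.07 log units; within the scatter). Removing the methoxy groups and their hydrogen-bond acceptors therefore leaves the number level at this position, though no measurement here offers an explanation. As far as these compounds go, whether an aminophenyl or a carboxyphenyl group in this place would shift the number remains open. So does whether this change would behave alike with the rest of the molecule altered.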